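Two Methyl Groups in Place of a Nitrile on the Sulfonyl

This account rests on a few compounds, and the source may have more. Where it says the series, first, only, none or still open, it means among the compounds named here.

Three measured compounds share one core and differ only in the aryl group on the sulfonyl sulfur. In an assay on isolated protein for displacement of a labelled ligand from metabotropic glutamate receptor 5 (Homo sapiens), with a stated time of 60 min, tested at 1 uM (a higher number here means more inhibition at the concentration tested (going by the name of the read-out), a lower number less inhibition), compound 1 `COc1ccc(S(=O)(=O)c2cnc3ccc(C)cc3c2N2CCC(C)CC2)cc1Cl` gives 93%, and compound 2 `Cc1ccc2ncc(S(=O)(=O)c3ccc(Cl)c(Cl)c3)c(N3CCC(C)CC3)c2c1` gives 82%. Compound 3 `Cc1ccc2ncc(S(=O)(=O)c3cccc(C#N)c3)c(N3CCC(C)CC3)c2c1` gives 52% in this assay, the lowest of the three: the step of a number 30 percentage points lower from compound 2 to compound 3 (beyond the scatter) and the step of a number 41 percentage points lower from compound 1 to compound 3 (beyond the scatter) both go beyond the scatter, so compound 3 stands clearly below its two neighbours.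

Compound 4 `Cc1cc(C)cc(S(=O)(=O)c2cnc3ccc(C)cc3c2N2CCC(C)CC2)c1` is the next step from compound 3; the change is 3,5-dimethylphenyl in place of 3-cyanophenyl on a sulfonyl sulfur. Among the measured compounds shown here, no measured pair involves a dimethylphenyl group, so the only guidance is that the two other substituted phenyl groups both gave markedly higher numbers than the 3-cyanophenyl of compound 3, by the amounts just stated. The expectation for compound 4 is therefore a step upward in this assay of roughly a number 25 percentage points higher from compound 3 to compound 4 (beyond the scatter), beyond the scatter but uncertain in size. Compound 4 is estimated at 77%, with a likely range from 55% to 93%.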

Compound 4, a percentage reported as inhibition, at one concentration (the size of the read-out at that concentration, not a potency): 80%
For compound 4 the middle estimate is 3 percentage points below the measured one; the range from low to high includes it.
By their numbers in this assay, from the lowest: compound 3; then compounds 4 and 2 (each within the scatter of the next); then compound 1.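

Removing the nitrile and adding two methyl groups restores much of the signal in this assay, with a number 28 percentage points higher from compound 3 to compound 4 (beyond the scatter), so the low number of compound 3 is not shared by every aryl group outside the two chlorine-bearing ones. The 3,5-dimethylphenyl group holds only carbon, yet a number 2 percentage points lower from compound 2 to compound 4 (within the scatter), which shows that chlorine is not required on this ring to reach the level of compound 2, while a number 13 percentage points lower from compound 1 to compound 4 (beyond the scatter) leaves the 3-chloro-4-methoxyphenyl group of compound 1 clearly ahead. Nothing available explains why these aryl groups differ.

Open, on these data alone, is whether one methyl group would serve as well as two. Also open, as far as these compounds go, is what a plain phenyl, or a phenyl carrying an amine or a carboxylic acid, would give on the sulfonyl sulfur.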